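The source may hold more compounds than are shown below. What is called first, only, known or untested is meant among the compounds shown, and "the series" means these compounds.

Measured in a functional assay on LNCaP cells (Homo sapiens) for antiproliferative activity, read by WST assay, with a stated time of 3 days; on this read-out lower numbers stand for stronger inhibition and higher numbers for weaker inhibition:
- compound 1 `CCCCCOc1c(-c2cc(OC)c(OC)c(OC)c2)oc2ccccc2c1=O`: 15400 nM
- compound 2 `CCCCCCCOc1c(-c2cc(OC)c(OC)c(OC)c2)oc2ccccc2c1=O`: > 50000 nM (a limit)
- compound 3 `CCC(C)Oc1c(-c2cc(OC)c(OC)c(OC)c2)oc2ccccc2c1=O`: 9300 nM

Compound 2 gives > 50000 nM, which is a limit of this assay and not a number. Compound 3 gives 9300 nM, the lower of the two actual numbers, but the gap to the other is only a 1.7-fold lower number from compound 1 to compound 3 (0.22 log units; within the scatter).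

The next change leads to compound 4 `CCCN(CCC)CCCCCOc1c(-c2cc(OC)c(OC)c(OC)c2)oc2ccccc2c1=O`, with 5-(dipropylamino)pentyl in place of sec-butyl on an oxygen on an aromatic ring.

Among the measured compounds shown here, two measured steps bear on chain length: an at least 3.2-fold higher number from compound 1 to compound 2 (0.51 log units; beyond the scatter) and an at least 5.3-fold lower number from compound 2 to compound 3 (0.73 log units; beyond the scatter). Neither compares a chain carrying an amine, so the direction is poorly defined and the range must stay wide. Compound 4 keeps the pentyl chain of compound 1, which gives 15400 nM, rather than the heptyl chain of compound 2. No step beyond the scatter is therefore expected, and the estimated change is a 1.6-fold lower number from compound 3 to compound 4 (0.19 log units; within the scatter).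

For compound 4 the expected value is 6000 nM, with an estimated range of 1500 nM to 25000 nM.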

Compound 4, half-maximal inhibitory concentration: 7600 nM
Estimate against measurement, compound 4: 1.3-fold (0.10 log units) below, within the range that was stated.
By their numbers in this assay, from the lowest: compounds 4, 3 and 1 (each within the scatter of the next, the first and the last beyond it). At a limit, above all of these: compound 2.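

In this assay, among the compounds shown here, dipropylamino on the pentyl chain is the first change on this oxygen to give a step beyond the scatter among actual numbers: a 2.0-fold lower number from compound 1 to compound 4 (0.31 log units; beyond the scatter). The larger 5-(dipropylamino)pentyl group still cannot be told apart from sec-butyl, as a 1.2-fold lower number from compound 3 to compound 4 (0.09 log units; within the scatter) stays within the scatter, so this position accepts an amine-bearing chain without a measurable loss against the branched group. The step of an at least 6.5-fold lower number from compound 2 to compound 4 (0.81 log units; beyond the scatter) gives only a minimum size, since its heptyl end is a limit and not a number: the limit of > 50000 nM in this assay, at which 1 of the 4 values shown sits.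

Open, on these data alone, is whether a shorter or longer chain carrying dipropylamino would behave as the plain chains do. Also open, as far as these compounds go, is whether dimethylamino, piperidine or a carboxylic acid on the pentyl chain would give a similar step.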